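Cyclopropyl for prenyl on a polyamine oxidase inhibitor

The source may report more compounds than this note shows. Statements on the series, on what has been measured and on what is new or still open speak of the compounds shown alone.

In an assay on isolated protein for inhibition of polyamine oxidase 1 (Zea mays), read by spectrophotometry, using a Dixon plot, at pH 6.5 (a lower number here means a stronger inhibitor, a higher number a weaker inhibitor), compound 1 `CC(C)=CCNC(=N)NCCCCCN` gives 10 nM and stands lowest of the three numbers. Compound 2 `CC(C)=CCNC(=N)NCCCCCCN` gives 22 nM, the step of a 2.2-fold higher number from compound 1 to compound 2 (0.34 log units; beyond the scatter), while compound 3 `CC(C)=CCNC(=N)NCCCCNC(=N)NCC=C(C)C` gives 1500 nM, far above compound 1. Compound 4 `N=C(NCCCCCN)NCC1CC1` differs from compound 1 by cyclopropyl in place of 2-methylprop-1-en-1-yl on a saturated chain carbon bound to an amine nitrogen. Going by the values given here, no measured step touches this place: the step from compound 1 to compound 2 alters the chain end, and compound 3 carries a second guanidine, so neither tells how this exchange will read. The substituent in compound 1 is kept in all measured compounds, so a modest loss is expected, a 3.0-fold higher number from compound 1 to compound 4 (0.48 log units; beyond the scatter). Compound 4 is therefore estimated at 30 nM, between 8 nM and 150 nM.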

Compound 4, inhibition constant: 2580 nM
Compound 4: middle estimate off by 86-fold (1.93 log units), on the low side; the whole stated range lies below it.
By their numbers in this assay, from the lowest: compound 1; then compound 2; then compounds 3 and 4 (each within the scatter of the next).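

In this assay the exchange of 2-methylprop-1-en-1-yl for cyclopropyl brings a 260-fold higher number from compound 1 to compound 4 (2.41 log units; beyond the scatter) and so weighs far more on the number than the change at the chain end, which gave a 2.2-fold higher number from compound 1 to compound 2 (0.34 log units; beyond the scatter) in the same compound series. This place, on a saturated chain carbon bound to an amine nitrogen, therefore does not accept every small carbon group alike. Nothing available explains this loss.

On these data alone, whether the double bond, the extra carbon or the three-membered ring decides the outcome stays open. So does how a saturated isobutyl group or a phenyl ring would read at this place.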